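Cytotoxicity of Two Measured Analogues and an Untested Third

This account rests on a few compounds, and the source may have more. Where it says the series, first, only, none or still open, it means among the compounds named here.

Compound 1 `Cc1cc(-c2ccc(F)cc2)cc(C)c1Nc1ccnc(Nc2ccc(C#N)cc2)n1`: 4170 nM
Compound 2 `COc1ccccc1-c1cc(C)c(Nc2ccnc(Nc3ccc(C#N)cc3)n2)c(C)c1`: 940 nM

In an ADME assay on MT4 cells (Homo sapiens) for cytotoxicity, read by MTT assay, with a stated time of 4 days (on this read-out higher numbers stand for lower toxicity in this test and lower numbers for higher toxicity in this test), compound 2 gives 940 nM, the lowest of the two numbers shown; the only step, a 4.4-fold lower number from compound 1 to compound 2 (0.65 log units; beyond the scatter), lies beyond the scatter. Compound 3 `Cc1cc(-c2cccc(C#N)c2)cc(C)c1Nc1ccnc(Nc2ccc(C#N)cc2)n1` differs from compound 2 by 3-cyanophenyl in place of 2-methoxyphenyl on an aromatic carbon. Within the data shown here, the one measured step at this aromatic carbon, a 4.4-fold lower number from compound 1 to compound 2 (0.65 log units; beyond the scatter), shows that exchanging this ring shifts the read-out modestly, but neither measured ring is 3-cyanophenyl, so direction is uncertain. Compound 3 is expected to move back toward compound 1 by a modest step, a 2.4-fold higher number from compound 2 to compound 3 (0.39 log units; beyond the scatter). The estimate for compound 3 in this assay is 2300 nM, within a range of 700 nM to 8000 nM.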

Compound 3, half-maximal cytotoxic concentration: 920 nM
Estimate against measurement, compound 3: 2.5-fold (0.40 log units) above, within the range that was stated.
By their numbers in this assay, from the lowest: compounds 3 and 2 (each within the scatter of the next); then compound 1.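

In this assay, the step of a 1.0-fold lower number from compound 2 to compound 3 (0.01 log units; within the scatter) shows that 3-cyanophenyl and 2-methoxyphenyl cannot be told apart on this aromatic carbon. The exchange of 4-fluorophenyl for 3-cyanophenyl, a 4.5-fold lower number from compound 1 to compound 3 (0.66 log units; beyond the scatter), shows that a second ring also lies beyond the scatter from compound 1, which now stands alone with the highest number. Nothing measured here gives a reason for this result.

The compounds shown leave open whether 4-fluorophenyl itself sets compound 1 apart, since each ring carries a different group in a different place. They also leave open where a phenyl ring bearing an amine or a carboxylic acid would fall.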